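The source may report more compounds than this note shows. Statements on the series, on what has been measured and on what is new or still open speak of the compounds shown alone.

Compound 1, `C/C=C\C(=O)Nc1cc(Nc2nccc(-c3cn(C)c4ccccc34)n2)c(OC)cc1N(C)CCN(C)C`, gives 6930 nM in a functional assay on HepG2 cells (Homo sapiens) for antiproliferative activity, read by MTT assay, with a stated time of 72 h; a higher number here means a weaker inhibitor, a lower number a stronger inhibitor.
Compound 2, `COc1cc(N(C)CCN(C)C)c(NC(=O)/C=C\C(C)C)cc1Nc1nccc(-c2cn(C)c3ccccc23)n1`, gives 4390 nM in this assay.

Compound 2 has the lower of the two numbers, but the step of a 1.6-fold lower number from compound 1 to compound 2 (0.20 log units; within the scatter) lies within the scatter, so the two cannot be ranked. Compound 3, `COc1cc(N(C)CCN(C)C)c(NC(=O)/C=C\C(C)C)cc1Nc1nccc(-c2cn(C)c3ccc(F)cc23)n1`, differs from compound 2 by fluoro in place of hydrogen on an aromatic carbon. Among the compounds with values here, no measured step touches this position; the only measured step, a 1.6-fold lower number from compound 1 to compound 2 (0.20 log units; within the scatter), concerns the chain and does not bear on it. For compound 3 the expectation is therefore no step beyond the scatter, a 1.0-fold higher number from compound 2 to compound 3 (0.00 log units; within the scatter), with an estimated value of 4400 nM and a range from 1500 nM to 13000 nM.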

Compound 3, half-maximal inhibitory concentration: 3920 nM
The estimate for compound 3 lay 1.1-fold (0.05 log units) above the measured number; measured number inside the range.
By their numbers in this assay, from the lowest: compounds 3, 2 and 1 (each within the scatter of the next).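

Within the data shown here, this is the first measured change on the aromatic ring rather than the chain. In this assay, fluoro in place of hydrogen on this aromatic carbon gives a 1.1-fold lower number from compound 2 to compound 3 (0.05 log units; within the scatter), so compound 2 and compound 3 cannot be told apart, and this one small atom shows no measurable effect here. No supporting measurement is available to explain this result.

The compounds shown leave open whether chloro, methoxy or an amine on this same carbon would move the number beyond the scatter. They also leave open whether fluoro would behave alike with the methyl-bearing chain of compound 1.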